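The source may report more compounds than this note shows. Statements on the series, on what has been measured and on what is new or still open speak of the compounds shown alone.

Compound 1 `CC[C@H](C)[C@@H](NCC(=O)NNC(=O)COc1ccc(-c2nc3ccccc3s2)cc1OC)C(=O)O` gives 1790 nM in a functional assay on MCF7 cells (Homo sapiens) for inhibition, read by MTT assay, with a stated time of 3 days; on this read-out higher numbers stand for weaker inhibition and lower numbers for stronger inhibition. Compound 2 `COc1cc(-c2nc3ccccc3s2)ccc1OCC(=O)NNC(=O)CN[C@@H](CS)C(=O)O` gives 1230 nM in this assay. Compound 3 `COc1cc(-c2nc3ccccc3s2)ccc1OCC(=O)NNC(=O)CN[C@@H](CS(=O)(=O)O)C(=O)O` gives 1870 nM in this assay.

Among these three numbers compound 1 stands second highest. Its nearest neighbour is compound 3, with a 1.0-fold higher number from compound 1 to compound 3 (0.02 log units; within the scatter), and its furthest is compound 2, with a 1.5-fold lower number from compound 1 to compound 2 (0.16 log units; within the scatter); both lie within the scatter, as does a 1.5-fold higher number from compound 2 to compound 3 (0.18 log units; within the scatter). The three compounds therefore cannot be ordered on these data.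

Compound 4 `CCOC(=O)[C@@H](NCC(=O)NNC(=O)COc1ccc(-c2nc3ccccc3s2)cc1OC)[C@@H](C)CC` differs from compound 1 in one place: 1-(ethoxycarbonyl)-2-methylbutyl in place of 1-carboxy-2-methylbutyl on an amine nitrogen. Every measured step also changes the group on that amine nitrogen, and none of them moved the number beyond the scatter; but none of them exchanges a carboxy for an ester, so they speak only loosely to this change. On that basis the step from compound 1 to compound 4 in this assay is expected to be a 1.0-fold higher number from compound 1 to compound 4 (0.00 log units; within the scatter), with no clear direction beyond the scatter. Compound 4 is accordingly estimated at 1800 nM, within a range from 700 nM to 4500 nM.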

Compound 4, half-maximal inhibitory concentration: 1950 nM
The estimate for compound 4 lay 1.1-fold (0.03 log units) below the measured number; the measured number falls inside the stated range.
By their numbers in this assay, from the lowest: compounds 2, 1, 3 and 4 (each within the scatter of the next).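

Among the compounds shown here, compound 4 carries an ester where the earlier compounds carry a free carboxy on the group at this amine nitrogen, and in this assay that exchange gives a step that stays within the scatter (a 1.1-fold higher number from compound 1 to compound 4 (0.04 log units; within the scatter)). The steps from the two other compounds also stay within the scatter (a 1.0-fold higher number from compound 3 to compound 4 (0.02 log units; within the scatter); a 1.6-fold higher number from compound 2 to compound 4 (0.20 log units; within the scatter)), so across these four compounds the 1-(ethoxycarbonyl)-2-methylbutyl group, which has no hydrogen-bond donor, cannot be told apart from the three groups that have a free carboxy. No supporting evidence bears on this result.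

The compounds shown leave open whether a primary amide or a benzyl ester in place of the ethyl ester would give a step beyond the scatter. They also leave open whether a free amine on a longer chain at this nitrogen would do so.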